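From isopropyl to tert-butyl at the assay limit

The compounds below may be only part of what the source reports. "The series", "measured", "known", "first", "only" and "open" are said of these compounds alone.

Measured in an ADME assay on HCT-116 cells (Homo sapiens) for cytotoxicity, read by CellTiter-Glo, with a stated time of 72 h; on this read-out higher numbers stand for weaker inhibition and lower numbers for stronger inhibition:
- compound 1 `CC1CCN(C2CCN(S(=O)(=O)c3ccc(C#N)cc3)CC2)CC1`: > 5000 nM
- compound 2 `CCCOc1ccc(S(=O)(=O)N2CCC(N3CCC(C)CC3)CC2)cc1`: > 5000 nM
- compound 3 `CC1CCN(C2CCN(S(=O)(=O)c3ccc(C(C)C)cc3)CC2)CC1`: > 5000 nM

Compound 3 gives > 5000 nM, which is a limit and not a number. It has no company other than limits: the limit of > 5000 nM in this assay, at which 3 of the 3 values shown sit.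

Compound 4 `CC1CCN(C2CCN(S(=O)(=O)c3ccc(C(C)(C)C)cc3)CC2)CC1` turns the isopropyl of compound 3 into tert-butyl: methyl in place of hydrogen on a saturated chain carbon bound to an aromatic carbon and two saturated chain carbons.

The closest measured changes also alter a group on an aromatic carbon, yet each is a step that the two limits leave unreadable from compound 1 to compound 3 or a step that the two limits leave unreadable from compound 2 to compound 3. Among the measured compounds shown here, no measured step therefore has a known size, and no step beyond the scatter is expected in this assay. The expected change is a step that the limit leaves unreadable from compound 3 to compound 4. Compound 4 is estimated at 7000 nM, within an expected range of 3000 nM to 16000 nM.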

Compound 4, half-maximal inhibitory concentration: > 5000 nM
Compound 4: no number, only a limit; the forecaster's own chance of this, stated with the estimate: 88%; the middle value lies beyond the limit too.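

Compound 4, like compound 1, compound 2 and compound 3, gives only a limit, so no step among them can be read: the limit of > 5000 nM in this assay, at which 4 of the 4 values shown sit.

As far as these compounds go, how far each compound lies past that limit stays open, and so does whether tert-butyl in place of isopropyl changes anything.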